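Adding methylsulfanyl to compound 2

A few compounds are considered here, and "the series" means these few. Any claim that something is new, unique, unknown or untested is made for them only; others in the source may bear on it.

Among the measured compounds shown here, in a functional assay on MCF7 cells (Homo sapiens) for cytotoxicity, read by MTT assay, with a stated time of 48 h (on this read-out lower numbers stand for stronger inhibition of growth and higher numbers for weaker inhibition of growth), compound 1 `FC(F)(F)c1nc2cc(Cl)c(Cl)cc2n1CC1CC1` gives 60200 nM and compound 2 `Clc1cc2ncn(C3CCCC3)c2cc1Cl` gives 42000 nM so the two values lie within the scatter of each other, and compound 2 stands level with the only other measured compound. Compound 3 `CSc1nc2cc(Cl)c(Cl)cc2n1C1CCCC1` differs from compound 2 in one place methylsulfanyl in place of hydrogen on an aromatic carbon with methylsulfanyl in place of hydrogen on an aromatic carbon, between two ring nitrogen atoms. For the measured compounds named here, no measured pair shows this change alone, so no step beyond the scatter is expected. The estimated move is a 1.2-fold lower number from compound 2 to compound 3 (0.07 log units; within the scatter) and no more. For compound 3 the expected value is 36000 nM with a likely range of 12000 nM to 90000 nM in this assay once it is measured.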

Compound 3, concentration for 50% growth inhibition: 3900 nM
For compound 3 the middle estimate is 9.2-fold (0.97 log units) above the measured one, and the stated range ends above it.
By their numbers in this assay, from the lowest: compound 3; then compounds 2 and 1 (each within the scatter of the next).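

Methylsulfanyl in place of hydrogen on an aromatic carbon, between two ring nitrogen atoms, brings an 11-fold lower number from compound 2 to compound 3 (1.03 log units; beyond the scatter), a large step beyond the scatter. The earlier compounds shown here differ in more than one place and could not isolate this position; this pair shows that growth inhibition responds strongly to what sits there. Nothing available here explains why this change has so large an effect. From the compounds shown here alone, whether an amine, a methoxy group or a longer chain on the sulfur would give a similar step remains open. So does whether the step would persist with another group in place of cyclopentyl.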